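A few compounds are considered here, and "the series" means these few. Any claim that something is new, unique, unknown or untested is made for them only; others in the source may bear on it.

Compound 2 `COc1ccc(C2CC(c3ccccc3)=NN2c2nc(-c3ccc(Cl)cc3)c(C#N)c(=O)n2C)cc1` gives 11000 nM in a functional assay on HT-29 cells (Homo sapiens) for antiproliferative activity, with a stated time of 72 h; on this read-out lower numbers stand for stronger inhibition and higher numbers for weaker inhibition. Compound 1 `COc1ccc(C2CC(c3ccccc3)=NN2c2nc(-c3ccccc3)c(C#N)c(=O)n2C)cc1` gives 14700 nM and compound 3 `Cn1c(N2N=C(c3ccccc3)CC2c2ccc(F)cc2)nc(-c2ccc(Cl)cc2)c(C#N)c1=O` gives 13700 nM, so the three numbers lie within the scatter of one another and no order among them is claimed. Compound 4 `COc1ccc(C2CC(c3ccc(Cl)cc3)=NN2c2nc(-c3ccc(Cl)cc3)c(C#N)c(=O)n2C)cc1` differs from compound 2 by chloro in place of hydrogen on an aromatic carbon, on a six-membered aromatic ring of carbon only, para to a large group; cut one bond further out, the change reads phenyl to 4-chlorophenyl. The same kind of change on the other phenyl, a 1.3-fold lower number from compound 1 to compound 2 (0.13 log units; within the scatter), stayed within the scatter, as did a 1.2-fold higher number from compound 2 to compound 3 (0.10 log units; within the scatter). A step of no size beyond the scatter is therefore expected, a 1.2-fold lower number from compound 2 to compound 4 (0.06 log units; within the scatter). Compound 4 is expected at 9500 nM in this assay, between 4000 nM and 22000 nM.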

Compound 4, half-maximal inhibitory concentration: 15100 nM
Estimate against measurement, compound 4: 1.6-fold (0.20 log units) below; low and high end bracket the measured number.
By their numbers in this assay, from the lowest: compounds 2, 3, 1 and 4 (each within the scatter of the next).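

In this assay, phenyl to 4-chlorophenyl at this position gives a 1.4-fold higher number from compound 2 to compound 4 (0.14 log units; within the scatter). This phenyl therefore takes a chloro with no step beyond the scatter, as the other phenyl did in a 1.3-fold lower number from compound 1 to compound 2 (0.13 log units; within the scatter), and compound 4 carries chloro on both rings without leaving the scatter of compound 2. No supporting measurement bears on this result. Still open, on these data alone, is whether a different group at this position, such as an amine, a carboxylic acid or a longer alkyl chain, would move the number beyond the scatter.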